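Halogen change on the terminal phenyl: compound 2 to compound 3

A few compounds are considered here, and "the series" means these few. Any claim that something is new, unique, unknown or untested is made for them only; others in the source may bear on it.

Measured so far:
Compound 1 `Oc1ccccc1/C=N/c1nnc(SCc2nnc(-c3ccccc3)o2)s1`: 7100 nM
Compound 2 `Oc1ccccc1/C=N/c1nnc(SCc2nnc(-c3ccc(F)cc3)o2)s1`: 13100 nM

Two compounds have been run in a functional assay on SMMC-7721 cells (Homo sapiens) for inhibition, read by CCK-8 assay; on this read-out higher numbers stand for weaker inhibition and lower numbers for stronger inhibition. Compound 2 gives the larger of the two numbers, but the step of a 1.8-fold higher number from compound 1 to compound 2 (0.27 log units; within the scatter) falls within the scatter, so the two compounds cannot be told apart on this read-out.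

Compound 3 `Oc1ccccc1/C=N/c1nnc(SCc2nnc(-c3ccccc3Cl)o2)s1` is the next member. It differs from compound 2 by 2-chlorophenyl in place of 4-fluorophenyl on an aromatic carbon. Within the data shown here, the only measured step that bears on this change is a 1.8-fold higher number from compound 1 to compound 2 (0.27 log units; within the scatter), which added a fluorine to the same phenyl ring and did not move the number beyond the scatter. Among the measured compounds shown here, no measured pair covers chlorine on this ring, nor a substituent at the 2-position of it, so the expectation rests on that single step alone. Compound 3 is therefore expected to show a 1.2-fold lower number from compound 2 to compound 3 (0.08 log units; within the scatter), a step no larger than the scatter in either direction. The estimate for compound 3 is 11000 nM, with a range of 4000 nM to 30000 nM that is widened because the chlorine and its 2-position are both untested.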

Compound 3, half-maximal inhibitory concentration: 31800 nM
Compound 3: middle estimate off by 2.9-fold (0.46 log units), on the low side; the whole stated range lies below it.
By their numbers in this assay, from the lowest: compounds 1 and 2 (each within the scatter of the next); then compound 3.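

In this assay, the terminal phenyl ring proves to be a place where a substituent can move the number beyond the scatter: 2-chlorophenyl in place of 4-fluorophenyl gives a 2.4-fold higher number from compound 2 to compound 3 (0.39 log units; beyond the scatter) and chloro in place of hydrogen gives a 4.5-fold higher number from compound 1 to compound 3 (0.65 log units; beyond the scatter) on the same ring. The fluorine step on this ring stayed within the scatter, so this ring does not accept every halogen change alike, and both steps that exceed the scatter point towards weaker inhibition. Nothing measured among these compounds explains why compound 3 stands apart.

Compound 2 and compound 3 differ in both the halogen and where it sits on the ring, so the compounds shown cannot separate the effect of chlorine from the effect of its position. Also open, from the compounds shown here alone, is whether a methoxy group or an amine on this ring would bring the number lower than that of the unsubstituted compound 1, which stands at 7100 nM and remains the reference for this ring.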